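Methyl for trifluoromethyl, carried over to a second core

A few compounds are considered here, and "the series" means these few. Any claim that something is new, unique, unknown or untested is made for them only; others in the source may bear on it.

Of the compounds shown here, three have been measured in a functional assay on HeLa cells (Homo sapiens) for antiproliferative activity, with a stated time of 24 h; a lower number here means a stronger inhibitor, a higher number a weaker inhibitor. Compound 1 `NC(=O)c1c(NC(=O)c2ccc(C(F)(F)F)cc2)sc2c1CCN(C(=O)Nc1ccccc1Cl)C2` carries a trifluoromethyl group, and in this assay compound 1 reaches only the limit of the assay, > 50000 nM, which is not a number. Compound 2 `Cc1ccc(C(=O)Nc2sc3c(c2C(N)=O)CCN(C(=O)Nc2ccccc2Cl)C3)cc1` differs from compound 1 by methyl in place of trifluoromethyl on an aromatic carbon, and in this assay compound 2 gives 32900 nM. Compound 3 `Cc1ccccc1C(=O)Nc1sc2c(c1C(N)=O)CCN(C(=S)Nc1ccccc1C(F)(F)F)C2` rests on another core; how the two cores differ is not broken down here. In this assay compound 3 also reaches only the limit of the assay, > 50000 nM, and that is a limit, not a number.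

Compound 4 `Cc1ccccc1NC(=S)N1CCc2c(sc(NC(=O)c3ccccc3C)c2C(N)=O)C1` is not yet measured. It differs from compound 3 by methyl in place of trifluoromethyl on an aromatic carbon. For the measured compounds named here, this is the same kind of change as the one from compound 1 to compound 2, but not the same change: in compound 2 the methyl sits para to a large group, in compound 4 ortho to a large group. The measured step was an at least 1.5-fold lower number from compound 1 to compound 2 (0.18 log units; that floor lies within the scatter). Beside it, the expected step is an at least 1.2-fold lower number from compound 3 to compound 4 (0.09 log units; that floor lies within the scatter), resting on that earlier step and on the fact that compound 3 sits at a limit. Compound 4 is estimated at 40000 nM, between 15000 nM and 100000 nM, and a real chance remains that only a limit is reported, as the limit of > 50000 nM in this assay, at which 2 of the 3 values shown sit, shows.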

Compound 4, half-maximal inhibitory concentration: > 50000 nM
Compound 4 was reported as a limit; the forecaster's own chance of this, stated with the estimate: 55%; middle value at least 1.2-fold (0.09 log units) from the limit.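

In this assay compound 3 gives > 50000 nM, which is a limit and not a number. For the compounds shown here, compound 4 gives > 50000 nM, also a limit and not a number, so no step from compound 3 to compound 4 can be read. The compounds shown leave open whether methyl in place of trifluoromethyl lowers the number on the core of compound 3, where the reading stops at the same limit: the limit of > 50000 nM in this assay, at which 3 of the 4 values shown sit.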